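The source may hold more compounds than are shown below. What is called first, only, known or untested is meant among the compounds shown, and "the series" means these compounds.

Measured compounds:
compound 1, `O=c1ccoc2cc(OCc3cn(Cc4ccccc4)nn3)ccc12`, > 100000 nM (a limit)
compound 2, `Cc1cccc(Cn2cc(COc3ccc4c(=O)ccoc4c3)nn2)c1`, > 100000 nM (a limit)
compound 3, `Cc1ccccc1Cn1cc(COc2ccc3c(=O)ccoc3c2)nn1`, 15300 nM

In a functional assay on HeLa cells (Homo sapiens) for cytotoxicity, read by MTT assay, with a stated time of 48 h (on this read-out higher numbers stand for weaker inhibition and lower numbers for stronger inhibition), compound 1 reaches only a limit of the assay, > 100000 nM. Compound 2 likewise gives only a limit, > 100000 nM. Going by the values given here, compound 3 is the single compound with a true number, 15300 nM, so it is the only fixed point among the three. Both measured steps that arrive at that number run the same way: an at least 6.5-fold lower number from compound 1 to compound 3 (0.81 log units; beyond the scatter), and an at least 6.5-fold lower number from compound 2 to compound 3 (0.81 log units; beyond the scatter). The step between compound 1 and compound 2 cannot be read, since both values are limits.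

Compound 4, `O=c1ccoc2cc(OCc3cn(Cc4cccc(F)c4)nn3)ccc12`, differs from compound 3 by 3-fluorophenyl in place of 2-methylphenyl on a saturated chain carbon bound to an aromatic nitrogen. In the pattern of its benzyl group compound 4 therefore resembles compound 2 more than compound 3, and compound 2 sat at the limit. The expectation is a step upward, a 3.9-fold higher number from compound 3 to compound 4 (0.59 log units; beyond the scatter), and a limit rather than a number is quite possible for compound 4 because the limit of > 100000 nM in this assay, at which 2 of the 3 values shown sit, is where two of the three values sit. The estimate for compound 4 is 60000 nM, expected between 20000 nM and 200000 nM.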

Compound 4, half-maximal inhibitory concentration: 7550 nM
The estimate for compound 4 lay 7.9-fold (0.90 log units) above the measured number; measured number outside the range, below it.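

In this assay, the 3-fluorophenyl group gives a true number where the unsubstituted phenyl and the 3-methylphenyl groups gave only limits: an at least 13-fold lower number from compound 1 to compound 4 (1.12 log units; beyond the scatter), and an at least 13-fold lower number from compound 2 to compound 4 (1.12 log units; beyond the scatter). A measurable effect on these cells is therefore no longer tied to the 2-methylphenyl group of compound 3, and swapping fluoro for methyl on the same ring changes the result sharply. The new group also goes somewhat further than the 2-methylphenyl group, with a 2.0-fold lower number from compound 3 to compound 4 (0.31 log units; beyond the scatter).

As far as these compounds go, the true size of the two larger steps stays open, since each starts from a limit rather than a number: the limit of > 100000 nM in this assay, at which 2 of the 4 values shown sit. Also open, from the compounds shown here alone, is whether a chlorine, a methoxy group or an amine on this ring would follow fluoro or methyl.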